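Swapping the benzyl group of compound 1

A few compounds are considered here, and "the series" means these few. Any claim that something is new, unique, unknown or untested is made for them only; others in the source may bear on it.

In a functional assay on RS4-11 cells (Homo sapiens) for inhibition, read by CCK-8 assay, with a stated time of 48 h, tested at 20 uM (on this read-out higher numbers stand for more inhibition of growth at the one concentration tested and lower numbers for less inhibition of growth), compound 1 (`COc1ccc(Cc2nnc(NC(=O)/C(C#N)=C/c3ccccc3OS(=O)(=O)c3ccc(OC)cc3)s2)cc1`) gives 78% and lies within the scatter of both other measured compounds. Compound 2 (`COc1ccc(Cc2nnc(NC(=O)/C(C#N)=C/c3ccccc3OS(=O)(=O)c3ccccc3[N+](=O)[O-])s2)cc1`) gives 68% and compound 3 (`COc1ccc(Cc2nnc(NC(=O)/C(C#N)=C/c3ccccc3OS(=O)(=O)c3ccc(F)cc3)s2)cc1`) gives 80% in the same test. Compound 4 (`COc1ccc(S(=O)(=O)Oc2ccccc2/C=C(\C#N)C(=O)Nc2nnc(Cc3cccc(F)c3)s2)cc1`) has not been measured. Its change is 3-fluorophenyl in place of 4-methoxyphenyl on a saturated chain carbon bound to an aromatic carbon and reads, in words, as 4-methoxybenzyl to 3-fluorobenzyl. All three measured steps alter the group on a sulfonyl sulfur, so none tests this place directly. Two of them are a number 10 percentage points lower from compound 1 to compound 2 (within the scatter) and a number 12 percentage points higher from compound 2 to compound 3 (beyond the scatter) as the group on that sulfur varies. The closest in kind, fluoro in place of methoxy on an aromatic carbon, is a number 2 percentage points higher from compound 1 to compound 3 (within the scatter) and offers only indirect guidance. On that basis no step beyond the scatter is expected, and the estimated step is a number 3 percentage points lower from compound 1 to compound 4 (within the scatter) in this assay with real uncertainty. For compound 4 the expected value is 75% with 58% to 88% as the estimated range.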

Compound 4, percent growth inhibition at one concentration: 74%
Estimate against measurement, compound 4: 1 percentage points above, within the range that was stated.
By their numbers in this assay, from the lowest: compounds 2, 4, 1 and 3 (each within the scatter of the next, the first and the last beyond it).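

The earlier steps shown here all vary the group on the sulfonyl sulfur, whereas this one alters the other end of the molecule: replacing 4-methoxybenzyl with 3-fluorobenzyl gives a number 4 percentage points lower from compound 1 to compound 4 (within the scatter) in this assay. At this place, then, 3-fluorophenyl can stand in for 4-methoxyphenyl with the two compounds indistinguishable in this test, so the methoxy group is not required for the growth inhibition seen here. The swap alters both the substituent and its numbered ring position, however, and no available measurement offers an explanation for the result.

The compounds shown leave open how much the substituent and its ring position each contribute, which 4-fluorobenzyl or 3-methoxybenzyl would help to separate. On these data alone, it also remains unknown whether this place accepts very different groups, such as an unsubstituted benzyl, a 4-aminobenzyl or a longer 2-phenylethyl chain.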